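The source may hold more compounds than are shown below. What is called first, only, known or untested is meant among the compounds shown, and "the series" means these compounds.

Of the compounds shown here, three sharing one core have been tested in a functional assay (aorta) for antagonist activity, with Oryctolagus cuniculus as the target; a higher number here means a weaker inhibitor, a lower number a stronger inhibitor. Compound 1 `CCCCc1ccc(CN(Cc2ccccc2)S(C)(=O)=O)c(=O)n1Cc1ccc(-c2ccccc2-c2nn[nH]n2)cc1` gives 2 nM, compound 2 `CCCCc1ccc(CN(C)S(=O)(=O)c2ccccc2)c(=O)n1Cc1ccc(-c2ccccc2-c2nn[nH]n2)cc1` gives 2 nM, and compound 3 `CCCCc1ccc(CNS(C)(=O)=O)c(=O)n1Cc1ccc(-c2ccccc2-c2nn[nH]n2)cc1` gives 2 nM. The three therefore stand level with one another: the step of no change at the digits printed from compound 1 to compound 2 (within the scatter) lies within the scatter, as do no change at the digits printed from compound 1 to compound 3 (within the scatter) and no change at the digits printed from compound 2 to compound 3 (within the scatter). Compound 3 sits at the same level as compounds 1 and 2, with compound 1 its nearest neighbour and compound 2 its furthest, both within the scatter.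

Compound 4 `CCCCc1ccc(CN(CC)S(C)(=O)=O)c(=O)n1Cc1ccc(-c2ccccc2-c2nn[nH]n2)cc1` has not yet been measured. It differs from compound 3 by ethyl in place of hydrogen on a sulfonamide nitrogen. The step that bears most directly on this change is no change at the digits printed from compound 1 to compound 3 (within the scatter), where a benzyl on the same sulfonamide nitrogen was exchanged for hydrogen without any effect beyond the scatter. Since both a large and a small substituent on that nitrogen gave the same reading, an ethyl there is expected to leave the value unchanged, so the expected step of no change at the digits printed from compound 3 to compound 4 (within the scatter) is none beyond the scatter. Compound 4 is thus estimated at 2 nM, with a range from 1 nM to 4 nM.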

Compound 4, half-maximal inhibitory concentration: 2 nM
Compound 4: the middle estimate sits on the measured number at the digits printed; low and high end bracket the measured number.
By their numbers in this assay, from the lowest: compounds 1, 2, 3 and 4 (each within the scatter of the next).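

In this assay, the ethyl on the sulfonamide nitrogen gives no change at the digits printed from compound 3 to compound 4 (within the scatter), so an unbranched alkyl chain now joins hydrogen and benzyl among the groups on that nitrogen that read level. The two wider exchanges agree: methyl in place of phenyl gives no change at the digits printed from compound 1 to compound 4 (within the scatter), and ethyl(methylsulfonyl)amino in place of methyl(phenylsulfonyl)amino gives no change at the digits printed from compound 2 to compound 4 (within the scatter). No supporting data bear on why these readings stand level.

On these data alone, the four compounds show no group on this nitrogen that moves the reading, so the limit of this tolerance remains unknown. As far as these compounds go, it remains open whether a longer chain or a carboxylic acid on the sulfonamide nitrogen, or an amine in place of the whole sulfonamide, would keep the value at this level.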